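The source may hold more compounds than are shown below. What is called first, only, known or untested is meant among the compounds shown, and "the series" means these compounds.

Working notes on the series in a functional assay on SMMC-7721 cells (Homo sapiens) for antiproliferative activity, read by MTT assay, with a stated time of 72 h; a lower number here means a stronger inhibitor, a higher number a weaker inhibitor. Compound 1 (`C/C(=N\NC(=O)c1cccc(S(=O)(=O)N2CCOCC2)c1)c1ccccc1O`) gives 1370 nM. For the measured compounds named here, compound 3 (`C/C(=N\NC(=O)c1cccc(S(=O)(=O)N2CCOCC2)c1)c1ccc(O)cc1`) gives 88500 nM, the higher of the two actual numbers so far. Compound 2 (`C/C(=N\NC(=O)c1cccc(S(=O)(=O)N2CCOCC2)c1)c1cccc(O)c1`) reads > 100000 nM, which is a limit of the assay and not a number.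

The measured steps all concern the place of the hydroxyl on the phenyl group. There is a 65-fold higher number from compound 1 to compound 3 (1.81 log units; beyond the scatter) and an at least 72-fold higher number from compound 1 to compound 2 (1.86 log units; beyond the scatter), both large, whereas an at least 1.1-fold lower number from compound 2 to compound 3 (0.05 log units; that floor lies within the scatter) has a floor within the scatter.

Compound 4 (`C/C(=N\NC(=O)c1cccc(S(=O)(=O)N2CCOCC2)c1)c1cc(F)ccc1O`) brings 5-fluoro-2-hydroxyphenyl in place of 4-hydroxyphenyl on a carbon with a double bond to nitrogen. Going by the values given here, no measured step covers the fluorine. The entering group keeps the 2-hydroxy naming of the 2-hydroxyphenyl in compound 1, so the large step of a 65-fold higher number from compound 1 to compound 3 (1.81 log units; beyond the scatter) is the one that bears on this change, read in reverse. The estimated step is a 59-fold lower number from compound 3 to compound 4 (1.77 log units; beyond the scatter), a large one towards a lower number. For compound 4 the expected value is 1500 nM, with an estimated range of 400 nM to 6000 nM.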

Compound 4, half-maximal inhibitory concentration: 1150 nM
The estimate for compound 4 lay 1.3-fold (0.12 log units) above the measured number; the range from low to high includes it.
By their numbers in this assay, from the lowest: compounds 4 and 1 (each within the scatter of the next); then compound 3. At a limit, above all of these: compound 2.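

In this assay, fluoro in place of hydrogen on an aromatic carbon gives a 1.2-fold lower number from compound 1 to compound 4 (0.08 log units; within the scatter), so the two cannot be told apart. The large step of a 77-fold lower number from compound 3 to compound 4 (1.89 log units; beyond the scatter) carries the contrast between hydroxyl places over to a second compound with a 2-hydroxy group, and none of the compounds shown goes against it. The step of an at least 86-fold lower number from compound 2 to compound 4 (1.93 log units; beyond the scatter) is only a floor, as it starts from a limit of the assay and not a number: the limit of > 100000 nM in this assay, at which 1 of the 4 values shown sits.

Open, going by these compounds, is whether a methoxy group or an amine in place of the hydroxyl of compound 1 would keep a number in the same region. Also open, on these data alone, is whether chloro or methyl in place of the fluoro of compound 4 would read as the fluoro does.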